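This account rests on a few compounds, and the source may have more. Where it says the series, first, only, none or still open, it means among the compounds named here.

In a functional assay on MCF7 cells (Homo sapiens) for inhibition, read by fluorescence, with a stated time of 72 h (a higher number here means a weaker inhibitor, a lower number a stronger inhibitor), compound 1 `CC(C)n1cnc2c(NC(=N)N)nc(N)nc21` gives 97200 nM. Compound 2 `CC[C@@H](N)COc1nc(NC(=N)N)c2ncn(C(C)C)c2n1` stands at > 100000 nM, which is a limit and not a number. Compound 3 `CC[C@@H](CO)Nc1nc(NC(=N)N)c2ncn(C(C)C)c2n1` carries (1-(hydroxymethyl)propyl)amino in place of 2-aminobutoxy on an aromatic carbon. For the measured compounds named here, only one measured step bears on this, 2-aminobutoxy in place of amino, and it reads an at least 1.0-fold higher number from compound 1 to compound 2 (0.01 log units; that floor lies within the scatter), a floor within the scatter. A small move towards a lower number is therefore expected in this assay, with the compound remaining a weak inhibitor. The expected change is an at least 1.4-fold lower number from compound 2 to compound 3 (0.15 log units; that floor lies within the scatter). For compound 3 the estimate is 70000 nM, within a range of 25000 nM to 150000 nM.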

Compound 3, half-maximal inhibitory concentration: 1600 nM
Beside the measured number, compound 3's estimate is 44-fold (1.64 log units) above it; measured number outside the range, below it.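

In this assay, the same atoms joined differently at this position, between two ring nitrogen atoms, separate a weak compound from a far stronger one: (1-(hydroxymethyl)propyl)amino in place of 2-aminobutoxy gives an at least 62-fold lower number from compound 2 to compound 3 (1.79 log units; beyond the scatter). Against plain amino, the chain joined through nitrogen gives a 61-fold lower number from compound 1 to compound 3 (1.78 log units; beyond the scatter), so how the chain is joined counts here, not merely its presence. The first step is only a floor: the limit of > 100000 nM in this assay, at which 1 of the 3 values shown sits.

The compounds shown leave open whether the hydroxyl is needed on this chain, as a methyl ether or a plain butylamino group would tell. They also leave open how a longer chain on the same nitrogen would read.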